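Swapping a Small Chain for a Benzyl Group

This account rests on a few compounds, and the source may have more. Where it says the series, first, only, none or still open, it means among the compounds named here.

In a functional assay on L1210 cells (Mus musculus) for cytotoxicity, read by cell counting, with a stated time of 2 days (a higher number here means a weaker inhibitor, a lower number a stronger inhibitor), compound 1 `CCN1C(=O)S/C(=C\c2ccc(N)cc2)C1=O` gives 82000 nM. Among the three measured compounds it holds the second highest number: compound 3 `Nc1cccc(/C=C2\SC(=O)N(Cc3cccc(F)c3)C2=O)c1` gives 199000 nM, and compound 2 `C=C(Br)C(=O)Nc1cccc(/C=C2\SC(=O)N(Cc3cccc(F)c3)C2=O)c1` gives 590 nM, so compound 1 sits far from compound 2 and close to compound 3. Among the compounds with values here, the only measured step, a 340-fold higher number from compound 2 to compound 3 (2.53 log units; beyond the scatter), concerns a change on the aromatic amine and not the group on the ring nitrogen, so no measured step bears directly on the change considered here.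

Compound 4 `Nc1ccc(/C=C2\SC(=O)N(Cc3ccccc3)C2=O)cc1` differs from compound 1 by phenyl in place of methyl on a saturated chain carbon bound to an amide-type nitrogen in a ring. Compound 3 carries a benzyl-type group on that nitrogen and, with its amine elsewhere on the ring, shows a number somewhat higher than compound 1. Taken together, these values suggest a step of modest size, if any, and compound 4 is expected to give roughly 100000 nM, a step of a 1.2-fold higher number from compound 1 to compound 4 (0.09 log units; within the scatter), within a range of 30000 nM to 300000 nM in this assay.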

Compound 4, half-maximal inhibitory concentration: 38000 nM
Estimate against measurement, compound 4: 2.6-fold (0.42 log units) above, within the range that was stated.
By their numbers in this assay, from the lowest: compound 2; then compound 4; then compound 1; then compound 3.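

In this assay, within the data shown here, the step from ethyl to benzyl on the amide-type nitrogen in a ring, a 2.2-fold lower number from compound 1 to compound 4 (0.33 log units; beyond the scatter), is the first measured step at this position, and it is modest but beyond the scatter. Adding the six-membered aromatic ring therefore lowers the number a little, yet this step is far smaller than a 340-fold higher number from compound 2 to compound 3 (2.53 log units; beyond the scatter), which concerns a nitrogen on an aromatic ring. No supporting data on the cause of the step from phenyl in place of methyl are available here.

As far as these compounds go, whether an amine or a longer chain in place of the phenyl would move the number further remains open. From the compounds shown here alone, it is also open whether (1-bromoethenyl)carbonyl on the nitrogen of compound 4 would bring a similarly large step.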